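Methoxyphenyl isomers on a thiocarbamoyl pyrazoline core

The source may report more compounds than this note shows. Statements on the series, on what has been measured and on what is new or still open speak of the compounds shown alone.

Measured compounds:
compound 1 `S=C(Nc1ccccc1)N1N=C(c2ccc(Cl)cc2)CC1c1ccc2c(c1)OCCO2` — > 200000 nM in a functional assay on HCT-116 cells (Homo sapiens) for antiproliferative activity, read by MTT assay, with a stated time of 48 h; on this read-out higher numbers stand for weaker inhibition of growth and lower numbers for stronger inhibition of growth
compound 2 `COc1ccccc1C1=NN(C(=S)Nc2ccccc2)C(c2ccc3c(c2)OCCO3)C1` — > 200000 nM in this assay

Compound 2 is known only as a limit in this assay. The value of compound 1 in this assay is also a limit. The step that the two limits leave unreadable from compound 1 to compound 2 therefore cannot be read. Both compounds sit at the limit of > 200000 nM in this assay, at which 2 of the 2 values shown sit.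

Compound 3 `COc1cccc(C2=NN(C(=S)Nc3ccccc3)C(c3ccc4c(c3)OCCO4)C2)c1` is not yet measured. It differs from compound 2 only in 3-methoxyphenyl in place of 2-methoxyphenyl on a carbon with a double bond to nitrogen. Within the data shown here, the one measured step that touches this carbon is unreadable, so the series gives no size for a change of the methoxyphenyl pattern at this place.

With both measured values at the limit, compound 3 is expected to remain around the limit as well, the estimated step being a step that the limit leaves unreadable from compound 2 to compound 3. The estimate for compound 3 in this assay is 300000 nM, with a range from 100000 nM to 1000000 nM; a further limit rather than a number is the more likely outcome.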

Compound 3, concentration for 50% growth inhibition: > 200000 nM
Compound 3 ended at the assay's limit (the forecaster's own chance of this, stated with the estimate: 85%); the middle value is on the limit's open side.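

In this assay compound 3 gives > 200000 nM, a limit and not a number, and the steps to compound 3 from compound 1 and from compound 2 cannot be read. The compounds shown leave open whether 4-chlorophenyl, 2-methoxyphenyl and 3-methoxyphenyl differ at all in growth inhibition on the shared core.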